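The source may hold more compounds than are shown below. What is called first, only, known or untested is meant among the compounds shown, and "the series" means these compounds.

Measured so far in a functional assay on UO-31 cells (Homo sapiens) for inhibition, read by sulforhodamine B assay, with a stated time of 48 h; a lower number here means a stronger inhibitor of growth, a higher number a weaker inhibitor of growth:
compound 1 `O=C(Nc1cccc(-n2cc(-c3ccncc3)c(-c3ccc(Cl)c(O)c3)n2)c1)Nc1cccc(C(F)(F)F)c1` gives 1860 nM
compound 2 `COc1cc(-c2nn(-c3cccc(NC(=O)Nc4cc(C(F)(F)F)cc(C(F)(F)F)c4)c3)cc2-c2ccncc2)ccc1Cl` gives 600 nM

Compound 2 stands at the lower of the two numbers in this assay; compound 1 sits higher, and the gap between the two lies beyond the usual scatter. The two differ in more than one place at once, so neither difference can be credited on its own.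

Compound 3 `O=C(Nc1cccc(-n2cc(-c3ccncc3)c(-c3ccc(Cl)c(O)c3)n2)c1)Nc1cc(C(F)(F)F)cc(C(F)(F)F)c1` is not yet measured. It differs from compound 2 in a single place: hydrogen in place of methyl on an oxygen on an aromatic ring. Compound 1 carries the same 4-chloro-3-hydroxyphenyl group together with a single trifluoromethyl group and gives the weaker number, so compound 3 is expected to land between the two measured values rather than below compound 2. The step of a 1.8-fold higher number from compound 2 to compound 3 (0.26 log units; within the scatter) is expected to be small, toward a higher number, and possibly within the scatter. For compound 3 the estimate in this assay is 1100 nM, in the range 400 nM to 3000 nM.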

Compound 3, concentration for 50% growth inhibition: 647 nM
Estimate against measurement, compound 3: 1.7-fold (0.23 log units) above, within the range that was stated.
By their numbers in this assay, from the lowest: compounds 2 and 3 (each within the scatter of the next); then compound 1.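

In this assay, methoxy to hydroxy gives a 1.1-fold higher number from compound 2 to compound 3 (0.03 log units; within the scatter), so with two trifluoromethyl groups in place the oxygen carries either methyl or hydrogen without a readable difference, which the earlier pair could not show, as compound 1 and compound 2 differ in more than one place. The added trifluoromethyl group on an aromatic carbon does register, with a 2.9-fold lower number from compound 1 to compound 3 (0.46 log units; beyond the scatter), a modest step beyond the scatter, so among these three compounds the earlier gap goes with that group and not with the group on the oxygen. Nothing available bears on the reason for either step.

Still open, on these data alone, is what an ethoxy group or a longer chain on the oxygen would do, or an amine in place of the hydroxy. Within the data shown here, also open is whether the methoxy to hydroxy result holds on the background of compound 1, with its single trifluoromethyl group.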